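The source may report more compounds than this note shows. Statements on the series, on what has been measured and on what is new or still open speak of the compounds shown alone.

Compound 1 `O=C(CSc1nncnc1-c1ccccc1Cl)Nc1ccccc1Br`: 73000 nM
Compound 2 `O=C(CSc1nncnc1-c1ccccc1Cl)Nc1ccccc1F`: 98000 nM
Compound 3 `O=C(CSc1nncnc1-c1ccccc1Cl)Nc1ccccn1`: 172000 nM

These three compounds share the same core and were all measured in an ADME assay on MT4 cells (Homo sapiens) for cytotoxicity, read by MTT assay; a higher number here means that more compound is tolerated, a lower number that less compound is tolerated. The numbers place compound 3 clearly apart from only one of the other two. The comparison with compound 1 shows a 2.4-fold higher number from compound 1 to compound 3 (0.37 log units; beyond the scatter), while the comparison with compound 2 shows a 1.8-fold higher number from compound 2 to compound 3 (0.24 log units; within the scatter), so that pair cannot be told apart.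

The next compound to be measured is compound 4 `O=C(CSc1nncnc1-c1ccccc1Cl)Nc1ccccc1Cl`, which has 2-chlorophenyl in place of pyridin-2-yl on an amide-type nitrogen. Its chloro group is a halogen, like the bromo of compound 1 and the fluoro of compound 2. Exchanging those two halogens gave a 1.3-fold higher number from compound 1 to compound 2 (0.13 log units; within the scatter), so the choice of halogen made no measurable difference in this small set. Compound 4 therefore seems likely to fall near compound 1 at 73000 nM and compound 2 at 98000 nM. This amounts to reading the two pyridin-2-yl steps backwards, although three compounds offer only thin support. The expected change is a 2.0-fold lower number from compound 3 to compound 4 (0.31 log units; beyond the scatter), a modest step toward a lower number. For compound 4, the estimated value is 85000 nM, with an expected range of 52000 nM to 135000 nM.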

Compound 4, half-maximal cytotoxic concentration: 90000 nM
Compound 4: the middle estimate sits 1.1-fold (0.02 log units) below what was measured; low and high end bracket the measured number.
By their numbers in this assay, from the lowest: compounds 1, 4, 2 and 3 (each within the scatter of the next, the first and the last beyond it).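

In this assay, a third halogen on the phenyl ring at this amide-type nitrogen again gives no separation, with a 1.1-fold lower number from compound 2 to compound 4 (0.04 log units; within the scatter) and a 1.2-fold higher number from compound 1 to compound 4 (0.09 log units; within the scatter) so that 2-bromophenyl, 2-fluorophenyl and 2-chlorophenyl cannot be told apart here. For the compounds shown here, the exchange of pyridin-2-yl for 2-chlorophenyl also stays within the scatter, at a 1.9-fold lower number from compound 3 to compound 4 (0.28 log units; within the scatter) and this adds a second such pair to the one formed by compound 2 and compound 3. Going by these compounds alone, the only step to or from compound 3 that clears the scatter remains a 2.4-fold higher number from compound 1 to compound 3 (0.37 log units; beyond the scatter) and the evidence available offers no explanation for any of these numbers.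

The compounds shown leave open whether anything other than a halogen or the pyridin-2-yl ring would shift the number at this place, such as 2-methoxyphenyl, a phenyl ring carrying a carboxylic acid, or a saturated cyclohexyl ring. They also leave open whether a group such as an amine on the phenyl ring would separate clearly from compound 3 in this assay or stay within the scatter as compound 4 does.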